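The source may report more compounds than this note shows. Statements on the series, on what has been measured and on what is new or still open speak of the compounds shown alone.

Compound 1 `COc1ccccc1C(=O)Nc1cccc(NC(=O)c2ccccc2Cl)c1` in an in vitro functional assay on HEK293-A cells for antagonist activity at metabotropic glutamate receptor 5 (Rattus norvegicus), read by calcium flux (on this read-out higher numbers stand for weaker inhibition and lower numbers for stronger inhibition), gives > 30000 nM, which is a limit of this assay rather than a number. Compound 2 `COc1ccccc1C(=O)Nc1cccc(NC(=O)c2ccco2)c1` in this assay gives > 30000 nM, likewise a limit. For the measured compounds named here, the one measured step, a step that the two limits leave unreadable from compound 1 to compound 2, is therefore unreadable, since both values sit at the limit of > 30000 nM in this assay, at which 2 of the 2 values shown sit. Compound 3 `COc1ccccc1C(=O)Nc1cccc(NC(=O)C2CCCCC2)c1` arises from compound 1 by the change (cyclohexyl in place of 2-chlorophenyl on a carbonyl carbon). Going by the values given here, no measured step bears readably on this change, so only the position of compound 1 guides the expectation. For compound 3 the expected value in this assay is 30000 nM, with a range from 8000 nM to 100000 nM, which would mean a step of a number no higher from compound 1 to compound 3 (the limit leaves the size open).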

Compound 3, half-maximal inhibitory concentration: > 30000 nM
Compound 3 gave a limit, no number (the forecaster's own chance of this, stated with the estimate: 75%); the middle value lies on the limit itself.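

Compound 3 gives > 30000 nM in this assay, again a limit. The steps among compound 1, compound 2 and compound 3 therefore cannot be read: the limit of > 30000 nM in this assay, at which 3 of the 3 values shown sit. On these data alone, how strongly these three compounds inhibit, and whether their carbonyl substituents differ at all, stays open.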